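Aryl ketone series: chloro to iodo on the phenyl ring

The source may hold more compounds than are shown below. What is called first, only, known or untested is meant among the compounds shown, and "the series" means these compounds.

Measured so far:
compound 1 `Cn1cccc1C(=O)/C=C/c1ccc2c(c1)B(O)OC2`: > 100000 nM
compound 2 `O=C(/C=C/c1ccc2c(c1)B(O)OC2)c1ccc(Cl)cc1`: 24700 nM

In a toxicity assay on WI-38 cells (Homo sapiens) for cytotoxicity, read by MTT assay, with a stated time of 48 h (a lower number here means a stronger inhibitor, a higher number a weaker inhibitor), compound 1 gives only > 100000 nM, which is a limit of the assay and not a number (the limit of > 100000 nM in this assay, at which 1 of the 2 values shown sits). In this assay compound 2 gives 24700 nM. Compound 2 thus holds the only number shown in this assay; the one further value is a limit. Going by the values given here, the single measured step, an at least 4.0-fold lower number from compound 1 to compound 2 (0.60 log units; beyond the scatter), exchanges the whole ring on the carbonyl carbon.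

Compound 3 `O=C(/C=C/c1ccc2c(c1)B(O)OC2)c1ccc(I)cc1` differs from compound 2 by iodo in place of chloro on an aromatic carbon. Among the compounds with values here, no measured step exchanges one halogen for another; the step from compound 1 to compound 2 concerns a different kind of change and bears on this one only loosely, so a step no larger than the scatter is expected in this assay, with at most a slight lean toward a lower number. Compound 3 is therefore expected to give 18000 nM in this assay, within a range from 6000 nM to 60000 nM. The expected step of a 1.4-fold lower number from compound 2 to compound 3 (0.14 log units; within the scatter) lies within the usual scatter.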

Compound 3, half-maximal inhibitory concentration: > 100000 nM
Compound 3 gave a limit, no number; the forecaster's own chance of this, stated with the estimate: 10%; at least 5.5-fold (0.74 log units) between middle value and limit.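

In this assay the exchange on this aromatic carbon, para to a large group, is not neutral: an at least 4.0-fold higher number from compound 2 to compound 3 (0.60 log units; beyond the scatter). Going by these compounds alone, the earlier step replaced the whole ring on the carbonyl carbon, so only this pair shows that the halogen alone can move the result beyond the scatter, and in the direction opposite to the one a single step might have suggested. The reading for compound 3 is a limit of the assay and not a number: the limit of > 100000 nM in this assay, at which 2 of the 3 values shown sit. Both ends of the step from compound 1 to compound 3 are limits and that step cannot be read, so among the compounds shown the measured number belongs to the 4-chlorophenyl group and cannot be extended to 4-halophenyl groups in general.

Going by these compounds, whether bromo or fluoro at this place would read like chloro or like iodo remains open, as does the behaviour of a methoxy group or an amine there. With a limit at one end, the full size of the step from chloro to iodo also stays unknown, and so does any cause for it.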